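Notes on the amide change from compound 2 to compound 4

The source may hold more compounds than are shown below. What is called first, only, known or untested is meant among the compounds shown, and "the series" means these compounds.

Measured so far:
- compound 1 `CCN(Cc1ccccc1)Cc1nc2ccccc2c(-c2ccccc2)c1C(=O)N(CC)CC`: in an assay on brain with Translocator protein (Rattus norvegicus) as the target (on this read-out lower numbers stand for stronger inhibition and higher numbers for weaker inhibition), compound 1 gives 373 nM
- compound 2 `CCN(Cc1ccccc1)Cc1nc2ccccc2c(-c2ccccc2)c1C(=O)NCc1ccccc1`: in this assay compound 2 gives 2900 nM
- compound 3 `CCN(CC)C(=O)c1cc(-c2ccccc2)c2ccccc2n1`: in this assay compound 3 gives 27 nM

Compound 2 stands highest of the three numbers in this assay; compound 1 is its nearest neighbour and compound 3 the furthest, with both gaps beyond the scatter. Compound 4 `CCN(Cc1ccccc1)Cc1nc2ccccc2c(-c2ccccc2)c1C(=O)N(C)c1ccc(Cl)cc1` is not yet measured. It differs from compound 2 in one place: (4-chlorophenyl)(methyl)amino in place of benzylamino on a carbonyl carbon. The hydrogen-bond donor of the benzylamino group leaves, and a chlorine enters with the new group.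

For the measured compounds named here, one measured step bears on this: a 7.8-fold higher number from compound 1 to compound 2 (0.89 log units; beyond the scatter), the move from diethylamino, which carries no hydrogen-bond donor, to benzylamino. Going by the values given here, no measured pair shows (4-chlorophenyl)(methyl)amino, nor a chlorine anywhere. Compound 3 differs from compound 2 in more than one place, so its value shows only what a diethylamino amide on a simpler core gives.

Because a 7.8-fold higher number from compound 1 to compound 2 (0.89 log units; beyond the scatter) accompanied the arrival of the donor, its removal in compound 4 is expected to bring the number back part of the way, a modest step in a 4.1-fold lower number from compound 2 to compound 4 (0.62 log units; beyond the scatter). Compound 4 is therefore estimated at 700 nM, within 150 nM to 3000 nM.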

Compound 4, half-maximal inhibitory concentration: 2480 nM
The estimate for compound 4 lay 3.5-fold (0.55 log units) below the measured number, and the stated range covers the measured number.
By their numbers in this assay, from the lowest: compound 3; then compound 1; then compounds 4 and 2 (each within the scatter of the next).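

In this assay, (4-chlorophenyl)(methyl)amino in place of benzylamino gives a 1.2-fold lower number from compound 2 to compound 4 (0.07 log units; within the scatter), so the two amides cannot be told apart at this carbonyl carbon even though the hydrogen-bond donor of benzylamino is gone. Losing that donor therefore does not by itself bring the number back towards that of the diethylamino amide, and the earlier step of a 7.8-fold higher number from compound 1 to compound 2 (0.89 log units; beyond the scatter) cannot be read as the work of the donor alone: a 6.6-fold higher number from compound 1 to compound 4 (0.82 log units; beyond the scatter) stays beyond the scatter with no donor on either side, which leaves diethylamino the only one of the three groups here to give a clearly lower number on the shared core. The data at hand offer nothing that explains this outcome.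

Still open, as far as these compounds go, is what the chlorine contributes, which methyl(phenyl)amino on the same carbonyl carbon would separate from the effect of the aryl ring itself. Also open, from the compounds shown here alone, is whether the lower number belongs to diethylamino in particular or extends to other simple dialkylamino groups such as dimethylamino or dipropylamino, or to a cyclic amine such as piperidine.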